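A few compounds are considered here, and "the series" means these few. Any claim that something is new, unique, unknown or untested is made for them only; others in the source may bear on it.

Compound 2 `CCCCn1nc(C(=O)N[C@H]2COc3ccccc3N(C)C2=S)nc1Cc1ccccc1` is the starting point, and compound 4 `CN1C(=S)[C@@H](NC(=O)c2nc(Cc3ccccc3)n(C3CCNC3)n2)COc2ccccc21` is the compound still to be tested. In a toxicity assay on HT-29 cells (Homo sapiens) for cytotoxicity (on this read-out lower numbers stand for higher toxicity in this test and higher numbers for lower toxicity in this test), compound 2 gives > 100000 nM, which is a limit of the test rather than a measured number. Compound 1 `CN1C(=S)[C@@H](NC(=O)c2nc(Cc3ccccc3)n(C)n2)COc2ccccc21` gives the limit > 100000 nM. Compound 3 `COCCn1nc(C(=O)N[C@H]2COc3ccccc3N(C)C2=S)nc1Cc1ccccc1` likewise gives the limit > 100000 nM. All three sit at the limit of > 100000 nM in this assay, at which 3 of the 3 values shown sit, so the steps a step that the two limits leave unreadable from compound 1 to compound 2, a step that the two limits leave unreadable from compound 1 to compound 3 and a step that the two limits leave unreadable from compound 2 to compound 3 cannot be read in size. The change to compound 4 is pyrrolidin-3-yl in place of butyl on an aromatic nitrogen. With every nearby step unreadable, no step beyond the scatter is foreseen in this assay. Compound 4 is therefore estimated at 100000 nM, in a range from 50000 nM to 200000 nM, an expected step of a number no higher from compound 2 to compound 4 (the limit leaves the size open).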

Compound 4, half-maximal cytotoxic concentration: > 100000 nM
Compound 4 was reported as a limit; the forecaster's own chance of this, stated with the estimate: 85%; the middle value sits exactly at the limit.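

In this assay, for the compounds shown here, compound 4 gives > 100000 nM, which is a limit, so no step linking it to compound 1, compound 2 or compound 3 can be read in size. The compounds shown leave open whether the group on the aromatic nitrogen affects toxicity in this assay at all.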